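Swapping a five-membered ring on the amide-side chain

The source may report more compounds than this note shows. Statements on the series, on what has been measured and on what is new or still open speak of the compounds shown alone.

This series shares one core, and the ring hung off a saturated chain carbon bound to an amide-type nitrogen is what varies. Compound 1 `CCN(Cc1c[nH]nn1)C(=O)COc1ccc(C)cc1` carries a triazole there; in an assay on HEK293 cells for agonist activity at transient receptor potential cation channel subfamily M member 8 (Homo sapiens), read by fluorescence and calcium flux, with a stated time of 15 min (on this read-out higher numbers stand for an effect only at larger amounts of compound and lower numbers for an effect already at smaller amounts), compound 1 gives 31100 nM. Compound 2 `CCN(Cc1cccn1C)C(=O)COc1ccc(C)cc1` carries a methylated pyrrole instead, and in this assay compound 2 gives 21300 nM. For the measured compounds named here, that is the lowest of the two numbers measured so far, but the step of a 1.5-fold lower number from compound 1 to compound 2 (0.16 log units; within the scatter) lies within the scatter, so the two compounds cannot be told apart on these data.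

Compound 3 `CCN(Cc1cn[nH]c1)C(=O)COc1ccc(C)cc1` has not yet been measured. It differs from compound 2 in one place: 1H-pyrazol-4-yl in place of 1-methyl-1H-pyrrol-2-yl on a saturated chain carbon bound to an amide-type nitrogen. Going by the values given here, the only step available for guidance is the ring swap from compound 1 to compound 2, which stayed within the scatter, and compound 3 again carries a small aromatic ring with nitrogen in it at the same place. The step of a 1.3-fold higher number from compound 2 to compound 3 (0.12 log units; within the scatter) is therefore expected to be small, with no clear direction beyond the scatter. For compound 3 in this assay the estimate is 28000 nM, with a range from 12000 nM to 65000 nM.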

Compound 3, half-maximal effective concentration: "active" (no number reported)
No number was reported for compound 3; the estimate stays without a comparison.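

In this assay, for the compounds shown here, compound 3 is recorded only as "active", without a number, so no step from compound 2 to compound 3 can be read. The compounds shown leave open how the 1H-pyrazol-4-yl ring of compound 3 compares numerically with the ring of compound 2. Nothing shown here bears on the reason for this result.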